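The source may report more compounds than this note shows. Statements on the series, on what has been measured and on what is new or still open speak of the compounds shown alone.

Measured compounds and their values:

Compound 1 `Fc1ccc(C2=NN(C(=S)Nc3ccccc3)C(c3ccc4c(c3)OCCO4)C2)cc1` gives 22500 nM in a functional assay on WM 266-4 cells (Homo sapiens) for antiproliferative activity, read by MTT assay, with a stated time of 48 h; a higher number here means a weaker inhibitor of growth, a lower number a stronger inhibitor of growth.
Compound 2 `S=C(Nc1ccccc1)N1N=C(c2ccccc2Br)CC1c1ccc2c(c1)OCCO2` gives > 200000 nM; this is a limit of the assay, not a number.
Compound 3 `COc1cccc(C2=NN(C(=S)Nc3ccccc3)C(c3ccc4c(c3)OCCO4)C2)c1` gives 1380 nM.

Among the numbers shown, compound 1 stands highest, so it is the weaker grower-inhibitor of the two that have a number. Its nearest neighbour is compound 3, reached by a 16-fold lower number from compound 1 to compound 3 (1.21 log units; beyond the scatter). Compound 2 sits at the limit of > 200000 nM in this assay, at which 1 of the 3 values shown sits, so only a limit is known for it.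

Compound 4 `Cc1ccc(C2=NN(C(=S)Nc3ccccc3)C(c3ccc4c(c3)OCCO4)C2)cc1C` has not yet been measured. It differs from compound 1 in one place: 3,4-dimethylphenyl in place of 4-fluorophenyl on a carbon with a double bond to nitrogen

Both measured steps from compound 1 change the group at this same place. One gave an at least 8.8-fold higher number from compound 1 to compound 2 (0.94 log units; beyond the scatter), the other 16-fold lower number from compound 1 to compound 3 (1.21 log units; beyond the scatter), so the choice of ring here matters, in both directions. A 3,4-dimethylphenyl has not been tested in this series, so the direction for compound 4 is uncertain. Compound 4 is therefore expected to give 15000 nM, in a range from 3000 nM to 80000 nM. That expectation corresponds to a 1.5-fold lower number from compound 1 to compound 4 (0.18 log units; within the scatter), a step that is expected to stay near the scatter.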

Compound 4, concentration for 50% growth inhibition: 70500 nM
Compound 4: the middle estimate sits 4.7-fold (0.67 log units) below what was measured; the range from low to high includes it.
By their numbers in this assay, from the lowest: compound 3; then compound 1; then compound 4. At a limit, above all of these: compound 2.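

In this assay, 3,4-dimethylphenyl in place of 4-fluorophenyl gives a 3.1-fold higher number from compound 1 to compound 4 (0.50 log units; beyond the scatter), so a ring with no halogen can also weaken growth inhibition at this place. Compared with the other two rings, the same group gives a 51-fold higher number from compound 3 to compound 4 (1.71 log units; beyond the scatter) and an at least 2.8-fold lower number from compound 2 to compound 4 (0.45 log units; beyond the scatter), so among these four rings only 3-methoxyphenyl gives a lower number than 4-fluorophenyl. The value for compound 2 is a limit of the assay, not a number: the limit of > 200000 nM in this assay, at which 1 of the 4 values shown sits.

Going by these compounds, what remains open is whether the low number of compound 3 depends on the methoxy group itself or on where it sits on the ring. On these data alone, how a phenyl ring carrying an amine or a carboxylic acid would behave at this place also remains unknown.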